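Cyclohexyl to 2,3-dihydro-1,4-benzodioxin-6-yl: a cytotoxicity estimate

The source may hold more compounds than are shown below. What is called first, only, known or untested is meant among the compounds shown, and "the series" means these compounds.

Of the compounds shown here, three sharing one core have been measured. Compound 1 `O=c1nc(NCc2ccc(F)cc2)oc2c([N+](=O)[O-])cc(C(F)(F)F)cc12` carries a 4-fluorophenyl on a saturated chain carbon bound to a nitrogen on an aromatic ring. In an ADME assay on Vero cells (Chlorocebus sabaeus) for cytotoxicity, read by MTT assay, with a stated time of 48 h (a higher number here means a weaker inhibitor, a lower number a stronger inhibitor), compound 1 gives > 64 ug/mL, which is a limit of the assay rather than a number (the limit of > 64 ug/mL in this assay, at which 1 of the 3 values shown sits). Compound 2 `CN(Cc1ccc2c(c1)OCCO2)c1nc(=O)c2cc(C(F)(F)F)cc([N+](=O)[O-])c2o1` gives 9.27 ug/mL in this assay. Compound 3 `O=c1nc(NCC2CCCCC2)oc2c([N+](=O)[O-])cc(C(F)(F)F)cc12`, with cyclohexyl at the same place, gives 29.7 ug/mL in this assay. Going by the values given here, the one single-point step recorded is an at least 2.1-fold lower number from compound 1 to compound 3 (0.33 log units; beyond the scatter), so exchanging the 4-fluorophenyl for cyclohexyl moved the number down. Among the two plain numbers, compound 3 stands highest, and compound 2 sits a step below it, beyond the scatter.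

Compound 4 `O=c1nc(NCc2ccc3c(c2)OCCO3)oc2c([N+](=O)[O-])cc(C(F)(F)F)cc12` is not yet measured. It differs from compound 3 by 2,3-dihydro-1,4-benzodioxin-6-yl in place of cyclohexyl on a saturated chain carbon bound to a nitrogen on an aromatic ring. Among the compounds with values here, this reverses the sense of the only recorded step, which went from an aromatic ring to cyclohexyl and lowered the number. At the same time compound 2, which also carries a 2,3-dihydro-1,4-benzodioxin group, gives 9.27 ug/mL, below compound 3. Weighing these, a modest decrease is expected, a 1.7-fold lower number from compound 3 to compound 4 (0.22 log units; within the scatter), and compound 4 is estimated at 18 ug/mL, within a range from 7 ug/mL to 50 ug/mL.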

Compound 4, half-maximal inhibitory concentration: 25.3 ug/mL
The estimate for compound 4 lay 1.4-fold (0.15 log units) below the measured number; the range from low to high includes it.
By their numbers in this assay, from the lowest: compound 2; then compounds 4 and 3 (each within the scatter of the next). At a limit, above all of these: compound 1.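

In this assay, a 1.2-fold lower number from compound 3 to compound 4 (0.07 log units; within the scatter), so at this place on the saturated chain carbon the 2,3-dihydro-1,4-benzodioxin-6-yl group cannot be told from cyclohexyl, although it brings an aromatic ring and hydrogen-bond acceptors that cyclohexyl lacks, while an at least 2.5-fold lower number from compound 1 to compound 4 (0.40 log units; beyond the scatter), which shows that two groups that both carry an aromatic ring need not read alike here. The reading for compound 1 is a limit of the assay and not a number: the limit of > 64 ug/mL in this assay, at which 1 of the 4 values shown sits. Going by these compounds alone, with the 2,3-dihydro-1,4-benzodioxin group held fixed, a 2.7-fold higher number from compound 2 to compound 4 (0.44 log units; beyond the scatter), the first sign that a change on the nitrogen itself, hydrogen in place of methyl, moves the number beyond the scatter, whereas the exchange of cyclohexyl for this group does not.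

That nitrogen step rests on a single pair, so the compounds shown leave open whether methyl on the nitrogen would lower the number in the same way with cyclohexyl or 4-fluorophenyl on the chain. They also leave open how the number would respond to a group of another kind at this place, such as a carboxylic acid, an amine or a longer chain.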